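Working notes on the amide series, compounds 1 to 4

The source may hold more compounds than are shown below. What is called first, only, known or untested is meant among the compounds shown, and "the series" means these compounds.

Measured so far:
compound 1, `O=C(Nc1ccc(Cl)c(-c2nnc3c(Cl)cccn23)c1)c1ccc(Cl)cc1`, 58400 nM
compound 2, `CS(=O)(=O)c1ccc(C(=O)Nc2ccc(Cl)c(-c3nnc4c(Cl)cccn34)c2)cc1`, 94200 nM
compound 3, `Cc1cc(Cl)ccc1C(=O)Nc1ccc(Cl)c(-c2nnc3c(Cl)cccn23)c1`, reported as a limit: > 100000 nM

All three were run in a functional assay on MCF7 cells (Homo sapiens) for antiproliferative activity, read by MTT assay, with a stated time of 72 h; on this read-out higher numbers stand for weaker inhibition and lower numbers for stronger inhibition. Compound 1 gives the lowest of the two numbers that are numbers, with compound 2 nearest at a 1.6-fold higher number from compound 1 to compound 2 (0.21 log units; within the scatter). Compound 3 reaches (the limit of > 100000 nM in this assay, at which 1 of the 3 values shown sits), so it is a limit rather than a number. For the measured compounds named here, the step of an at least 1.7-fold higher number from compound 1 to compound 3 (0.23 log units; that floor lies within the scatter) thus has only a floor, as does an at least 1.0-fold higher number from compound 2 to compound 3 (0.02 log units; that floor lies within the scatter); both floors and the one full step sit inside the scatter, so the three measured compounds cannot be told apart in this assay.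

Compound 4, `O=C(Nc1ccc(Cl)c(-c2nnc3c(Cl)cccn23)c1)c1ccccc1Cl`, differs from compound 1 by 2-chlorophenyl in place of 4-chlorophenyl on a carbonyl carbon. Going by the values given here, the steps that bear on it are those altering the same aryl group on the carbonyl carbon: a 1.6-fold higher number from compound 1 to compound 2 (0.21 log units; within the scatter), an at least 1.7-fold higher number from compound 1 to compound 3 (0.23 log units; that floor lies within the scatter) and an at least 1.0-fold higher number from compound 2 to compound 3 (0.02 log units; that floor lies within the scatter). None of them shows a change beyond the scatter, though the limit of compound 3 leaves open that a number above it may follow. No step beyond the scatter is therefore expected in this assay, with the uncertainty leaning toward a higher number.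

Compound 4 is expected to give 80000 nM, between 30000 nM and 180000 nM, which would be a step of a 1.4-fold higher number from compound 1 to compound 4 (0.14 log units; within the scatter).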

Compound 4, half-maximal inhibitory concentration: 92200 nM
Compound 4: middle estimate off by 1.2-fold (0.06 log units), on the low side; the measured number falls inside the stated range.
By their numbers in this assay, from the lowest: compounds 1, 4 and 2 (each within the scatter of the next). At a limit, above all of these: compound 3.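

Compound 4 has the same atoms as compound 1, and with 2-chlorophenyl in place of 4-chlorophenyl on a carbonyl carbon, this assay gives a 1.6-fold higher number from compound 1 to compound 4 (0.20 log units; within the scatter). Unlike the earlier steps, this one changes only where the chlorine sits on the aryl group, and a full number on both sides shows that this change does not move the result beyond the scatter. Against the 4-(methylsulfonyl)phenyl group the picture is the same, with a 1.0-fold lower number from compound 2 to compound 4 (0.01 log units; within the scatter), so compounds 1, 2 and 4 cannot be told apart here. Compound 3 stands at a limit, so its step has only a floor (an at least 1.0-fold lower number from compound 3 to compound 4 (0.03 log units; that floor lies within the scatter)), and that floor is all that can be read: the limit of > 100000 nM in this assay, at which 1 of the 4 values shown sits.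

Every aryl group shown on this carbonyl carbon carries only chloro, methyl or methylsulfonyl, so it remains open whether an amine or a carboxylic acid on that ring would give a step beyond the scatter. As far as these compounds go, it is equally open whether a longer chain in place of the aryl group would do so.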